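Moving the benzyl chlorine: compound 3 to compound 4

This account rests on a few compounds, and the source may have more. Where it says the series, first, only, none or still open, it means among the compounds named here.

Compound 3 `CCN(Cc1cccc(Cl)c1)C(=O)C1CCN(S(=O)(=O)c2ccc3cn[nH]c3c2)CC1` gives 77% in a functional assay on CHO cells for positive allosteric modulation of muscarinic acetylcholine receptor M5 (Homo sapiens), read by calcium flux (on this read-out lower numbers stand for smaller maximal responses and higher numbers for larger maximal responses), the second highest of the three numbers. Compound 1 `CCN(Cc1ccccc1)C(=O)C1CCN(S(=O)(=O)c2ccc(OC)cc2)CC1` gives 84%, within the scatter of compound 3, while compound 2 `CCN(Cc1ccccc1)C(=O)C1CCN(S(=O)(=O)c2ccc(C)s2)CC1` gives 64%, beyond the scatter and lower. Going by the values given here, the only measured step, a number 20 percentage points lower from compound 1 to compound 2 (beyond the scatter), concerns the group on the sulfonyl sulfur and not the benzyl side of the amide. Compound 4 `CCN(Cc1ccccc1Cl)C(=O)C1CCN(S(=O)(=O)c2ccc3cn[nH]c3c2)CC1` differs from compound 3 by 2-chlorophenyl in place of 3-chlorophenyl on a saturated chain carbon bound to an amide-type nitrogen. No measured pair varies the chlorobenzyl group, so nothing shown bears directly on this change; the expectation is a step no larger than the scatter, a number 2 percentage points lower from compound 3 to compound 4 (within the scatter), in either direction. Compound 4 is therefore estimated at 75%, with a range from 60% to 90%.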

Compound 4, largest response reached (reported as percent of maximum), in percent of the reference or control that the assay uses: 93%
The estimate for compound 4 lay 18 percentage points below the measured number; measured number outside the range, above it.
By their numbers in this assay, from the lowest: compound 2; then compounds 3, 1 and 4 (each within the scatter of the next, the first and the last beyond it).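

In this assay the chlorobenzyl side of the amide proves sensitive to where the chlorine sits: 3-chlorobenzyl to 2-chlorobenzyl gives a number 16 percentage points higher from compound 3 to compound 4 (beyond the scatter) and is the first step shown on this side, the earlier one concerning only the group on the sulfonyl sulfur. The two compounds have the same atoms, joined differently, so rearrangement alone shifts the maximal response here. Nothing available explains this step.

Open, on these data alone, is whether 2-chlorobenzyl gives a similar step with 4-methoxyphenyl or 5-methylthiophen-2-yl on the sulfonyl sulfur. Also open, as far as these compounds go, is how a methoxybenzyl group or a longer phenethyl chain would read at this place.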